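Swapping the aryl amine in a trifluoromethylbenzyl thioether series

The source may report more compounds than this note shows. Statements on the series, on what has been measured and on what is new or still open speak of the compounds shown alone.

Compound 1 `FC(F)(F)c1ccc(CSc2nc(Nc3ccccc3C(F)(F)F)c3ccccc3n2)cc1`: 34800 nM
Compound 2 `FC(F)(F)c1ccc(CSc2nc(Nc3ccc(Cl)cc3)c3ccccc3n2)cc1`: 7110 nM

The two measured compounds share one core and differ only in the aryl group on the nitrogen on the aromatic ring. In a functional assay on PC-3 cells (Homo sapiens) for cytotoxicity, read by MTT assay, with a stated time of 72 h (a higher number here means a weaker inhibitor, a lower number a stronger inhibitor), compound 1 gives 34800 nM. In this assay compound 2 gives 7110 nM, the lowest of the two numbers shown, and the single step of a 4.9-fold lower number from compound 1 to compound 2 (0.69 log units; beyond the scatter) is the only one available for judging this position.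

Compound 3 `COc1ccc(Nc2nc(SCc3ccc(C(F)(F)F)cc3)nc3ccccc23)c(OC)c1` continues the same variation: 2,4-dimethoxyphenyl in place of 4-chlorophenyl on a nitrogen on an aromatic ring. Among the measured compounds shown here, the one step that bears on this change is a 4.9-fold lower number from compound 1 to compound 2 (0.69 log units; beyond the scatter), which shows that the aryl group on that nitrogen can move the number modestly. It does not tell which way a dimethoxy-substituted ring will move it. With nothing to point the step in a clear direction, a small change is expected, and the estimate is placed a little toward weaker inhibition, with a wide range. Compound 3 is therefore expected to give 12000 nM in this assay, between 4000 nM and 40000 nM, a step of a 1.7-fold higher number from compound 2 to compound 3 (0.23 log units; within the scatter).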

Compound 3, half-maximal inhibitory concentration: 32500 nM
The estimate for compound 3 lay 2.7-fold (0.43 log units) below the measured number; low and high end bracket the measured number.
By their numbers in this assay, from the lowest: compound 2; then compounds 3 and 1 (each within the scatter of the next).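

In this assay, the change to 2,4-dimethoxyphenyl gives a 4.6-fold higher number from compound 2 to compound 3 (0.66 log units; beyond the scatter), showing that a different aryl group on this nitrogen can undo the whole gain that 4-chlorophenyl had shown. The new comparison with the first compound gives a 1.1-fold lower number from compound 1 to compound 3 (0.03 log units; within the scatter), so 2-(trifluoromethyl)phenyl and 2,4-dimethoxyphenyl cannot be told apart here, although the two rings carry different groups, and compound 2 alone stands apart, with its steps to both others beyond the scatter. Nothing available explains why 4-chlorophenyl differs from the other two aryl groups.

The compounds shown leave open whether the lower number belongs to the chlorine itself, since an unsubstituted phenyl, a 4-fluorophenyl or a 4-methoxyphenyl on the same nitrogen could separate the effect of the single chlorine from that of the other rings. They also leave open whether the same order of aryl groups would hold if the 4-(trifluoromethyl)benzyl group on the sulfur were replaced by a plain benzyl group.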